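The source may hold more compounds than are shown below. What is called first, only, known or untested is meant among the compounds shown, and "the series" means these compounds.

Measured in an ADME assay on L6 cells (Rattus norvegicus) for cytotoxicity, read by fluorescence and resazurin assay, with a stated time of 72 h; on this read-out lower numbers stand for higher toxicity in this test and higher numbers for lower toxicity in this test:
Compound 1 `N#Cc1ccc(C(c2ccn(-c3ccc(Cl)cc3)c2)n2ccnc2)cc1`: 42400 nM
Compound 2 `N#Cc1ccc(C(c2ccn(-c3ccc(C#N)cc3)c2)n2ccnc2)cc1`: 139000 nM

Compound 1 stands lowest of the two, with compound 2 its nearest neighbour. Compound 3 `CC(C)(C)c1ccc(C(c2ccn(-c3ccc(Cl)cc3)c2)n2ccnc2)cc1` carries tert-butyl in place of cyano on an aromatic carbon of compound 1: tert-butyl in place of cyano on an aromatic carbon. Among the measured compounds shown here, only one measured step bears on this, and only indirectly: a 3.3-fold higher number from compound 1 to compound 2 (0.52 log units; beyond the scatter). It is modest, and there cyano entered elsewhere in the molecule. Here cyano leaves, so a modest step towards a lower number is expected in this assay, though with wide uncertainty. The estimated value for compound 3 is 20000 nM, with an expected range from 6000 nM to 60000 nM. This estimate means a 2.1-fold lower number from compound 1 to compound 3 (0.33 log units; beyond the scatter).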

Compound 3, half-maximal cytotoxic concentration: 46400 nM
Compound 3: the middle estimate sits 2.3-fold (0.37 log units) below what was measured; the range from low to high includes it.
By their numbers in this assay, from the lowest: compounds 1 and 3 (each within the scatter of the next); then compound 2.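

In this assay, putting tert-butyl in place of cyano on this aromatic carbon gives a 1.1-fold higher number from compound 1 to compound 3 (0.04 log units; within the scatter), so compound 1 and compound 3 cannot be told apart here. Among the compounds shown here, the earlier step, a 3.3-fold higher number from compound 1 to compound 2 (0.52 log units; beyond the scatter), lay beyond the scatter but at another place in the molecule, so this is the first reading at this position, and here a group with no hydrogen-bond acceptor stands in for one with an acceptor. Nothing at hand explains this result. As far as these compounds go, whether an amine or a carboxylic acid at this position would stay within the scatter of compound 1 remains open.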